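The source may report more compounds than this note shows. Statements on the series, on what has been measured and on what is new or still open speak of the compounds shown alone.

Measured so far in a functional assay on Caco-2 cells (Homo sapiens), read by fluorescence, tested at 10 uM; a lower number here means a stronger effect, a higher number a weaker effect of the compound at the concentration tested:
- compound 1 `CCCNC(=C\C(=O)/C=C/c1ccc(O)c(OC)c1)/C=C/c1ccc(O)c(OC)c1`: 88%
- compound 2 `COc1cc(/C=C/C(=O)/C=C(/C=C/c2ccc(OC(C)=O)c(OC)c2)NCC(C)C)ccc1OC(C)=O`: 77%

Compound 1 gives the highest of the two numbers in this assay; the nearest, compound 2, gives a number lower by a margin beyond the usual scatter. Compound 2 differs from compound 1 in more than one place, so its value is not a clean guide for a single change.

The next compound, compound 3 `COc1cc(/C=C/C(=O)/C=C(/C=C/c2ccc(O)c(OC)c2)NCC(C)C)ccc1O`, differs from compound 1 only as follows: methyl in place of hydrogen on a saturated chain carbon bound to two saturated chain carbons. Going by the values given here, no measured pair shows this change on its own. A small step is expected in this assay, within the scatter, if anything toward a slightly lower number. The step from a number 4 percentage points lower from compound 1 to compound 3 (within the scatter) is the estimate here. Compound 3 is expected to give about 84% in this assay, with a range from 72% to 95%.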

Compound 3, a percentage reported as activity, at one concentration (the size of the read-out at that concentration, not a potency): 74%
Beside the measured number, compound 3's estimate is 10 percentage points above it, and the stated range covers the measured number.
By their numbers in this assay, from the lowest: compounds 3 and 2 (each within the scatter of the next); then compound 1.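

In this assay, going by these compounds alone, the change from propylamino to isobutylamino gives a number 14 percentage points lower from compound 1 to compound 3 (beyond the scatter) and is the first step that can be read from a single change. It shows that this position is not silent: one methyl in place of hydrogen on a saturated chain carbon bound to two saturated chain carbons is enough to move the number beyond the scatter, toward a stronger effect at the concentration tested. Nothing shown here accounts for the step.

From the compounds shown here alone, this direction rests on one pair, so it remains open whether a longer chain such as butylamino, or a ring-bearing group such as cyclopropylmethylamino, would move the number further. Also open, going by these compounds, is whether a hydroxyethylamino group in the same place would keep or reverse the step.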